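From Butyl to Isobutyl on a Sulfonamide

A few compounds are considered here, and "the series" means these few. Any claim that something is new, unique, unknown or untested is made for them only; others in the source may bear on it.

Measured in a functional assay on HeLa cells (Homo sapiens) for antiproliferative activity, read by CCK-8 assay, with a stated time of 72 h; on this read-out higher numbers stand for weaker inhibition of growth and lower numbers for stronger inhibition of growth:
- compound 1 `CCCCNS(=O)(=O)c1ccc(Nc2ncc3c(n2)N(C2CCCC2)[C@H](CC)C(=O)N3C)cc1`: 451 nM
- compound 2 `CC[C@@H]1C(=O)N(C)c2cnc(-n3ccc4cc(C(=O)NCC(C)C)ccc43)nc2N1C1CCCC1`: 3280 nM

Compound 1 has the lower number of these two, and the number for compound 2 lies higher, beyond the usual scatter. Compound 3 `CC[C@@H]1C(=O)N(C)c2cnc(Nc3ccc(S(=O)(=O)NCC(C)C)cc3)nc2N1C1CCCC1` has the same atoms as compound 1, joined differently: isopropyl in place of propyl on a saturated chain carbon bound to a sulfonamide nitrogen. In words, isopropyl stands in place of propyl on a saturated chain carbon bound to a sulfonamide nitrogen, so butylsulfamoyl becomes isobutylsulfamoyl. Among the compounds with values here, no measured pair shows this change, so the expectation in this assay is no shift beyond the scatter, and the expected step is small: a 1.1-fold higher number from compound 1 to compound 3 (0.04 log units; within the scatter). For compound 3 the estimated value is 500 nM, with an expected range of 200 nM to 1300 nM.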

Compound 3, concentration for 50% growth inhibition: 561 nM
Compound 3: the middle estimate sits 1.1-fold (0.05 log units) below what was measured, and the stated range covers the measured number.
By their numbers in this assay, from the lowest: compounds 1 and 3 (each within the scatter of the next); then compound 2.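

In this assay replacing butylsulfamoyl with isobutylsulfamoyl gives a 1.2-fold higher number from compound 1 to compound 3 (0.09 log units; within the scatter) so on this read-out the butyl and isobutyl chains cannot be told apart at this place. Within the data shown here, this is the first measured pair at this position, and it covers only a rearrangement of the same atoms on a saturated chain carbon bound to a sulfonamide nitrogen. No measurement here offers an explanation for this result.
Going by these compounds, whether a shorter chain such as methyl, a longer chain such as hexyl, or a chain ending in an amine or a carboxylic acid would shift the number remains open.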